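A few compounds are considered here, and "the series" means these few. Any claim that something is new, unique, unknown or untested is made for them only; others in the source may bear on it.

Compound 1, `COc1ccc(CNc2nc3cc(N)cc(N)c3nc2-c2ccccc2)cc1OC`, is measured in a functional assay on UO-31 cells (Homo sapiens) for inhibition, read by sulforhodamine B assay, with a stated time of 48 h; on this read-out lower numbers stand for higher toxicity in this test and higher numbers for lower toxicity in this test. Its result in this assay is a limit rather than a number: compound 1 gives < 100000 nM. Within the data shown here, compound 2, `COc1cc(CNc2nc3cc(N)cc(N)c3nc2-c2ccccc2)cc(OC)c1OC`, is the only other measured compound, and it too stops at a limit in this assay, where compound 2 gives < 50200 nM. Among the measured compounds shown here, the one measured step, a step that the two limits leave unreadable from compound 1 to compound 2, is therefore not readable in size or direction, since both ends rest on limits (the limit of < 100000 nM in this assay, at which 1 of the 2 values shown sits, and (the limit of < 50200 nM in this assay, at which 1 of the 2 values shown sits)). Compound 1 thus stands on a limit alone, with nothing above or beneath it to fix its place.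

The step that this account follows leads to compound 3, `COc1ccc(CNc2nc3cc(N)cc(N)c3nc2-c2ccccc2)cc1`, which is not yet measured in this assay. The change is hydrogen in place of methoxy on an aromatic carbon, so the 3,4-dimethoxyphenyl becomes a 4-methoxyphenyl. For the measured compounds named here, no measured step speaks to removing a methoxy group from this ring, and the one step that exists is unreadable. Compound 3 is therefore expected to sit near the limit of compound 1, with the step that the limit leaves unreadable from compound 1 to compound 3 estimated as essentially none beyond the scatter, and compound 3 is estimated at 40000 nM, between 8000 nM and 100000 nM.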

Compound 3, concentration lethal to 50% of the cells: 72400 nM
Compound 3: the middle estimate sits 1.8-fold (0.26 log units) below what was measured; the measured number falls inside the stated range.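

No new step can be read in this assay: compound 3 has a number, but compound 1 rests on a limit, so the size and direction of the step between compound 1 and compound 3 stay unreadable. The compounds shown leave open whether changing the number of methoxy groups on this ring alters the read-out at all.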